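A few compounds are considered here, and "the series" means these few. Any claim that something is new, unique, unknown or untested is made for them only; others in the source may bear on it.

For the measured compounds named here, in a functional assay on MCF7 cells (Homo sapiens) for cytotoxicity, read by MTT assay, with a stated time of 96 h (a higher number here means a weaker inhibitor, a lower number a stronger inhibitor), two compounds have numbers so far. Compound 1 (`COc1cc(C(=O)c2cn(-c3cccc(F)c3)cc2-c2ccccc2[N+](=O)[O-])cc(OC)c1OC`) gives 190 nM, and compound 2 (`COc1cc(C(=O)c2cn(-c3ccc(C)cc3)cc2-c2ccccc2F)cc(OC)c1OC`) gives 44 nM. This is the lower of the two numbers, which makes compound 2 the stronger inhibitor, by a gap beyond the scatter. Compound 3 (`COc1cc(C(=O)c2cn(-c3ccc(C)cc3)cc2-c2ccccc2[N+](=O)[O-])cc(OC)c1OC`) has not yet been measured. It departs from compound 2 by one exchange, nitro in place of fluoro on an aromatic carbon, ortho to a large group: nitro in place of fluoro on an aromatic carbon. Going by the values given here, no measured pair isolates this exchange, so the expectation is a loose one. Among the compounds with values here, compound 1, the only nitro compound with a number, stands at 190 nM, which points to a moderate rise in this assay, probably just beyond the scatter. The expected change is a 2.3-fold higher number from compound 2 to compound 3 (0.36 log units; beyond the scatter). For compound 3 the estimate is 100 nM, with an expected range from 35 nM to 280 nM.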

Compound 3, half-maximal inhibitory concentration: 65 nM
Beside the measured number, compound 3's estimate is 1.5-fold (0.19 log units) above it, within the range that was stated.
By their numbers in this assay, from the lowest: compounds 2 and 3 (each within the scatter of the next); then compound 1.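

In this assay, nitro in place of fluoro on the aromatic carbon ortho to a large group gives a 1.5-fold higher number from compound 2 to compound 3 (0.17 log units; within the scatter), so the 2-fluorophenyl and 2-nitrophenyl compounds cannot be told apart here. The gap between compound 1 and compound 2 spanned two places, but with nitro held constant, 4-methylphenyl in place of 3-fluorophenyl on the aromatic nitrogen gives a 2.9-fold lower number from compound 1 to compound 3 (0.47 log units; beyond the scatter), a change in one place that lies beyond the scatter. Nothing in the data given here explains either step.

The compounds shown carry only fluoro and nitro at this position, so how an amine or a carboxylic acid there would read stays open. Also open, on these data alone, is whether the exchange on the aromatic nitrogen gives a similar step when fluoro replaces nitro.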